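Nitrone series: tert-butyl for phenyl on compound 1

The source may hold more compounds than are shown below. What is called first, only, known or untested is meant among the compounds shown, and "the series" means these compounds.

Three members of the series have been run in a functional assay on A549 cells (Homo sapiens) for inhibition, read by MTT assay, with a stated time of 24 h; a lower number here means a stronger inhibitor, a higher number a weaker inhibitor. Compound 1 `CCCCCCCCCCn1cc(/C=[N+](\[O-])c2ccccc2)nn1` returns only a limit in this assay, > 100000 nM. Compound 2 `COc1ccc(-n2cc(/C=[N+](\[O-])Cc3ccccc3)nn2)cc1` likewise returns only a limit, > 100000 nM. Compound 3 `CC(C)(C)/[N+]([O-])=C/c1cn(-c2ccc(F)cc2)nn1` gives a measured value in this assay of 87000 nM. Compound 1 therefore stands at the limit of > 100000 nM in this assay, at which 2 of the 3 values shown sit; it cannot be ranked against compound 2, and the number for compound 3 lies close to that ceiling, so no order among the three can be drawn.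

Compound 4 `CCCCCCCCCCn1cc(/C=[N+](\[O-])C(C)(C)C)nn1` is the next member. Relative to compound 1 the change is tert-butyl in place of phenyl on a double-bonded nitrogen. Going by the values given here, no pair of measured compounds isolates this change, so there is no measured step to lean on. Compound 3 carries the same tert-butyl group on a double-bonded nitrogen and reaches only 87000 nM in this assay, which gives no sign that this group by itself brings the series into a measurable range. The expected step is a number no higher from compound 1 to compound 4 (the limit leaves the size open), no larger than the scatter. Compound 4 is accordingly estimated at 100000 nM, within 40000 nM to 300000 nM, with a real chance that this assay again reports only a limit.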

Compound 4, half-maximal inhibitory concentration: 24800 nM
For compound 4 the middle estimate is 4.0-fold (0.61 log units) above the measured one; the measured number lies below the stated range.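

Going by these compounds alone, on a double-bonded nitrogen, tert-butyl in place of phenyl gives an at least 4.0-fold lower number from compound 1 to compound 4 (0.60 log units; beyond the scatter) in this assay, the only step at this position that can be read so far, and it brings compound 4 to a measured number. As far as these compounds go, its full size stays open, as compound 1 returns only a limit: the limit of > 100000 nM in this assay, at which 2 of the 4 values shown sit. The tert-butyl group does not set the number by itself: with that group held, and one other place changed, compound 3 gives 87000 nM and compound 4 gives 24800 nM.

Still open, from the compounds shown here alone, is whether the gain belongs to tert-butyl specifically or would also appear with another non-aromatic group on this nitrogen, such as isopropyl or cyclohexyl, or with a substituted phenyl carrying an amine or a carboxylic acid. Also open, going by these compounds, is how the chain carried by compound 4 on the shared core compares with a shorter or longer chain when the tert-butyl group stays in place, and whether any such change moves the number further from the limit.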